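The source may hold more compounds than are shown below. What is called first, only, known or untested is meant among the compounds shown, and "the series" means these compounds.

Compound 1, with the structure `CC1=C(C(=O)OCc2ccccc2)C(c2ccco2)NC(=S)N1`, was tested in an assay on membranes from HEK293 cells for displacement of a labelled ligand from adenosine receptor A2b (Homo sapiens), read by scintillation counting, with a stated time of 30 min, tested at 1 uM (a higher number here means more inhibition at the concentration tested (going by the name of the read-out), a lower number less inhibition), where compound 1 gives 41%. Compound 2, whose structure is `CC1=C(C(=O)OCc2ccccc2)C(c2ccoc2)NC(=S)N1`, carries the same core but with the change (furan-3-yl in place of furan-2-yl on a saturated ring carbon); in this assay compound 2 gives 36%. The step between them, a number 5 percentage points lower from compound 1 to compound 2 (within the scatter), is therefore small, and the two values cannot be told apart with confidence.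

Compound 3, with the structure `COC(=O)C1=C(C)N(C)C(=O)NC1c1ccco1`, rests on a different core; how its core differs from that of compound 1 is not broken down here. In this assay compound 3 gives 31%, a value that sits within the scatter of both compound 1 and compound 2.

Compound 4, with the structure `COC(=O)C1=C(C)N(C)C(=O)NC1c1ccoc1`, has not yet been measured. It relates to compound 3 through the change (furan-3-yl in place of furan-2-yl on a saturated ring carbon). This is the same kind of change as that from compound 1 to compound 2, but the surroundings are not identical: in compound 3 the neighbouring ring atom bears a methoxycarbonyl group, and the place is also three ring bonds from the ring atom that bears a methyl group, whereas in compound 1 the neighbouring ring atom bears a large group. Within the data shown here, the expected step is a number 3 percentage points lower from compound 3 to compound 4 (within the scatter), resting on the single earlier example because the step of a number 5 percentage points lower from compound 1 to compound 2 (within the scatter) was small. Compound 4 is thus expected to give about 28% in this assay, estimated to lie between 15% and 42%.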

Compound 4, a percentage reported as inhibition, at one concentration (the size of the read-out at that concentration, not a potency): 7%
Compound 4: the middle estimate sits 21 percentage points above what was measured; the measured number lies below the stated range.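

In this assay, putting furan-3-yl in place of furan-2-yl on the core of compound 3 gives a number 24 percentage points lower from compound 3 to compound 4 (beyond the scatter). The same swap of furan rings therefore does not carry over at the same size from one core to the other: the same change on two cores in this assay, a number 5 percentage points lower (within the scatter) from compound 1 to compound 2 and a number 24 percentage points lower (beyond the scatter) from compound 3 to compound 4, 19 percentage points apart, beyond the scatter of two such steps. Among these compounds, this shows that a step read on one core is a poor guide to the step on the other, but it rests on only two pairs, and the two cores differ in more than one place, so it does not show which part of the core matters, nor what the swap would do on a third core.

What the compounds shown leave open is how the swap behaves on a core that differs from that of compound 3 in one place only, for example one that keeps everything but replaces the methoxycarbonyl group with a benzyl ester. Also open, as far as these compounds go, is how a thiophene or phenyl ring on the same saturated ring carbon, or a carboxylic acid in place of the methoxycarbonyl group, would read in this assay.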